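The source may report more compounds than this note shows. Statements on the series, on what has been measured and on what is new or still open speak of the compounds shown alone.

Among the three compounds measured so far, compound 3 `COc1ccc2nc(C)cc(OCC(=O)Nc3c(C)cncc3C)c2c1` stands lowest in a physicochemical assay for solubility, in phosphate buffer, measured as kinetic solubility, with a stated time of 1 h, at pH 7.4 (on this read-out lower numbers stand for lower solubility and higher numbers for higher solubility), at 12000 nM. Compound 1 `COc1ccc2nc(C)cc(OCC(=O)Nc3cc(C)c(F)c(C)c3)c2c1` gives 31500 nM in this assay, and compound 2 `COc1ccc2nc(C)cc(OCC(=O)Nc3ccc(Cl)cc3Cl)c2c1` gives 20500 nM. The distance from compound 1 to compound 3 is the only one that clears the scatter: a 2.6-fold lower number from compound 1 to compound 3 (0.42 log units; beyond the scatter). The other two steps, a 1.5-fold lower number from compound 1 to compound 2 (0.19 log units; within the scatter) and a 1.7-fold lower number from compound 2 to compound 3 (0.23 log units; within the scatter), both fall within it.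

Compound 4 `COc1ccc2nc(C)cc(OCC(=O)Nc3cc(C)nc(C)n3)c2c1` differs from compound 3 in one place: 2,6-dimethylpyrimidin-4-yl in place of 3,5-dimethylpyridin-4-yl on an amide-type nitrogen. The two measured steps that end at compound 3 both swap the ring on the amide-type nitrogen, and both move the number down, one beyond the scatter and one within it. Neither adds a second ring nitrogen, so they bear on the present change only loosely. On this basis the step from compound 3 to compound 4 is expected to stay within the scatter, leaning slightly downward, as a 1.2-fold lower number from compound 3 to compound 4 (0.08 log units; within the scatter). Compound 4 is therefore estimated at 10000 nM, with a likely range from 4000 nM to 25000 nM.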

Compound 4, solubility: 5000 nM
Estimate against measurement, compound 4: 2.0-fold (0.30 log units) above; measured number inside the range.
By their numbers in this assay, from the lowest: compound 4; then compounds 3, 2 and 1 (each within the scatter of the next, the first and the last beyond it).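

At this place on the amide-type nitrogen, 2,6-dimethylpyrimidin-4-yl brings a ring with 2 hetero atoms, and in this assay the change gives a 2.4-fold lower number from compound 3 to compound 4 (0.38 log units; beyond the scatter). Set against the rings with no ring nitrogen, the fall is larger, with a 4.1-fold lower number from compound 2 to compound 4 (0.61 log units; beyond the scatter) and a 6.3-fold lower number from compound 1 to compound 4 (0.80 log units; beyond the scatter), so compound 4 is the only compound here beyond the scatter of all the others. No measurement shown here accounts for this fall.

The change from 3,5-dimethylpyridin-4-yl to 2,6-dimethylpyrimidin-4-yl alters the ring nitrogens and the places of the methyl groups together, so the compounds shown cannot separate the two. On these data alone, how this read-out would respond to an amine or a carboxylic acid on this ring also remains open.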